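Benzamido in place of a pyrazolylethoxy group at the saturated carbon

A few compounds are considered here, and "the series" means these few. Any claim that something is new, unique, unknown or untested is made for them only; others in the source may bear on it.

Compound 2 `Cc1nn(-c2ncnc3nc[nH]c23)c2c1C(OCCn1nccc1C)CC(=O)N2`: 10 nM
Compound 1 `Cc1nn(-c2ncnc3nc[nH]c23)c2c1C(c1ccc(OC(C)C)cc1)CC(=O)N2`: 18 nM

In a functional assay on HEK293 cells for agonist activity at G-protein coupled receptor 39 (Homo sapiens), read by scintillation proximity assay and inositol phosphate accumulation, with a stated time of 75 min, in the presence of a further agent that is not named here (a higher number here means that more compound is needed for the effect, a lower number that less compound is needed), compound 2 gives 10 nM, the lowest of the two numbers; compound 1 gives 18 nM, and the step of a 1.8-fold lower number from compound 1 to compound 2 (0.26 log units; within the scatter) is within the scatter. Compound 3 `Cc1nn(-c2ncnc3nc[nH]c23)c2c1C(NC(=O)c1ccccc1)CC(=O)N2` carries the change (a group of 9 heavy atoms (7 carbon, 1 nitrogen, 1 oxygen; one six-membered aromatic ring of carbon only) in place of a group of 9 heavy atoms (6 carbon, 2 nitrogen, 1 oxygen; one five-membered aromatic ring with 2 hetero atoms), on a saturated ring carbon). Going by the values given here, only the step from compound 1 to compound 2 bears on a replacement at this carbon, and it was within the scatter. Compound 3 is therefore expected to stay close, with perhaps a modest move upward given the new amide linkage: the step of a 3.0-fold higher number from compound 2 to compound 3 (0.48 log units; beyond the scatter) is the estimate, giving compound 3 an expected 30 nM (range 8 nM to 120 nM).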

Compound 3, half-maximal effective concentration: 3 nM
The estimate for compound 3 lay 10-fold (1.00 log units) above the measured number; the whole stated range lies above it.
By their numbers in this assay, from the lowest: compound 3; then compounds 2 and 1 (each within the scatter of the next).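

In this assay, going by these compounds alone, a change at this saturated ring carbon moves the number beyond the scatter for the first time: benzamido gives a 3.3-fold lower number from compound 2 to compound 3 (0.52 log units; beyond the scatter) and a 6.0-fold lower number from compound 1 to compound 3 (0.78 log units; beyond the scatter) in this comparison. The position is therefore not indifferent to its substituent, as the earlier step within the scatter could have suggested. No measurement available here accounts for the difference. The compounds shown leave open whether the gain follows the amide or the phenyl ring; an acetamido group or a cyclohexanecarboxamido group would separate the two.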